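Side-Chain Swap in a Flat Three-Compound Series

The compounds below may be only part of what the source reports. "The series", "measured", "known", "first", "only" and "open" are said of these compounds alone.

In a functional assay on HepG2 cells (Homo sapiens) for inhibition, read by MTT assay, with a stated time of 3 days (on this read-out higher numbers stand for weaker inhibition and lower numbers for stronger inhibition), compound 1 (`COc1cc(-c2nc3ccccc3s2)ccc1OCC(=O)NNC(O)CN(C)CC(=O)O`) gives 3030 nM, compound 2 (`COc1cc(-c2nc3ccccc3s2)ccc1OCC(=O)NNC(=O)CN[C@@H](CS)C(=O)O`) gives 3120 nM, and compound 3 (`COc1cc(-c2nc3ccccc3s2)ccc1OCC(=O)NNC(=O)CN[C@@H](CS(=O)(=O)O)C(=O)O`) gives 3690 nM. Compound 3 thus stands within the scatter of both others. Compound 4 (`CCOC(=O)CN(C)CC(=O)NNC(=O)COc1ccc(-c2nc3ccccc3s2)cc1OC`) differs from it by ((ethoxycarbonyl)methyl)(methyl)amino in place of (1-carboxy-2-sulfoethyl)amino on a saturated chain carbon bound to a carbonyl carbon, with ((ethoxycarbonyl)methyl)(methyl)amino in place of (1-carboxy-2-sulfoethyl)amino on a saturated chain carbon bound to a carbonyl carbon. Among the measured compounds shown here, two measured steps bear on this change: a 1.0-fold higher number from compound 1 to compound 2 (0.01 log units; within the scatter) and a 1.2-fold higher number from compound 2 to compound 3 (0.07 log units; within the scatter). Both lie within the scatter, so no step beyond the scatter is expected in this assay. For the measured compounds named here, no measured compound carries the ethoxycarbonyl group, so the range stays wide. The estimated step is a 1.1-fold lower number from compound 3 to compound 4 (0.04 log units; within the scatter). Compound 4 is expected at 3400 nM, with an estimated range of 1600 nM to 7500 nM.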

Compound 4, half-maximal inhibitory concentration: 3180 nM
Compound 4: the middle estimate sits 1.1-fold (0.03 log units) above what was measured; measured number inside the range.
By their numbers in this assay, from the lowest: compounds 1, 2, 4 and 3 (each within the scatter of the next).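

In this assay, compound 4 brings ethoxycarbonyl into this side chain in place of a free carboxy group, yet it stays level with the other compounds (a 1.2-fold lower number from compound 3 to compound 4 (0.06 log units; within the scatter); a 1.0-fold higher number from compound 2 to compound 4 (0.01 log units; within the scatter); a 1.0-fold higher number from compound 1 to compound 4 (0.02 log units; within the scatter)). The flat picture at this saturated chain carbon bound to a carbonyl carbon therefore extends to an entering group with no hydrogen-bond donors. Nothing available explains this flatness.

On these data alone, whether a piperidine or a plain dimethylamino group at this place would keep the same level remains open. So does whether changes to the shared core would shift the read-out.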